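Trimming a cyclopropylmethyl group to cyclopropyl

The source may report more compounds than this note shows. Statements on the series, on what has been measured and on what is new or still open speak of the compounds shown alone.

Measured so far in a physicochemical assay for lipophilicity, using the shake flask method; a higher number here means a more lipophilic compound, a lower number a more polar compound:
- compound 1 `C[C@H](Oc1ccc(/C=C/C(=O)O)c(CC2CC2)c1)c1c(Cl)ccc(F)c1Cl` gives 3.9 here
- compound 2 `C[C@H](Oc1ccc2ncc(/C=C/c3nn[nH]n3)c(C3CC3)c2c1)c1c(Cl)cccc1Cl` gives 4.3 here

Of these two numbers, compound 1 holds the lower one, and the gap to compound 2 lies beyond the usual scatter of repeated measurements. The two compounds differ in more than one place, so their gap cannot be tied to any single change.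

Compound 3 `C[C@H](Oc1ccc(/C=C/C(=O)O)c(C2CC2)c1)c1c(Cl)ccc(F)c1Cl` keeps the shared core of compound 1 and changes one group: cyclopropyl in place of cyclopropylmethyl on an aromatic carbon with cyclopropyl in place of cyclopropylmethyl on an aromatic carbon. Within the data shown here, no measured pair here shows this change alone, so what follows is an expectation only. The expected step is a number 0.30 log units lower from compound 1 to compound 3 (within the scatter) in this assay and would be a small fall close to the edge of the scatter. The estimate for compound 3 is 3.6 with an expected range from 3.2 to 4 on this scale.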

Compound 3, distribution coefficient: 3.6
The estimate for compound 3 equals the measured number at the digits printed; the measured number falls inside the stated range.
By their numbers in this assay, from the lowest: compounds 3 and 1 (each within the scatter of the next); then compound 2.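

In this assay, the swap of cyclopropylmethyl for cyclopropyl on this aromatic carbon, ortho to a 2-carboxyethenyl group, gives a number 0.30 log units lower from compound 1 to compound 3 (within the scatter). Among these compounds, compound 1 and compound 3 are the first pair here that differ in one place, so this gap, unlike the one between compound 1 and compound 2, can be tied to a single change, and on this scale that change leaves the two compounds indistinguishable. Nothing else measured here explains the size of this step.

The compounds shown leave open how this assay would respond at this position to a group with a different make-up, such as an amine, a methoxy group or a longer chain like n-butyl. They also leave open whether the same swap would give a similar step on a different core, such as that of compound 2.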